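The source may report more compounds than this note shows. Statements on the series, on what has been measured and on what is new or still open speak of the compounds shown alone.

Measured so far:
- compound 1, `CCCCc1ccc2[nH]c(-c3ccc(OC)cc3)c(/C=N/NC(=O)c3ccc(Cl)cc3)c2c1`: 220 nM
- compound 2, `CCCCc1ccc2[nH]c(-c3ccc(C(F)(F)F)cc3)c(/C=N/NC(=O)c3ccc(Cl)cc3)c2c1`: 1060 nM
- compound 3, `CCCCc1ccc2[nH]c(-c3ccc(OC)cc3)c(/C=N/NC(=O)c3cccc(OC)c3)c2c1`: "not determined" (no result reported)

The read-out throughout is a functional assay on MCF7 cells (Homo sapiens) for antiproliferative activity, with a stated time of 5 days; on this read-out higher numbers stand for weaker inhibition and lower numbers for stronger inhibition. Among the two compounds with a number, compound 2 stands highest, and its only neighbour is compound 1, which lies lower by a 4.8-fold higher number from compound 1 to compound 2 (0.68 log units; beyond the scatter). Compound 3 carries no number in this assay, so it adds nothing to the comparison.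

Compound 4, `CCCCc1ccc2[nH]c(-c3ccc(C(F)(F)F)cc3)c(/C=N/NC(=O)c3cccnc3)c2c1`, is made from compound 2 by a single change: pyridin-3-yl in place of 4-chlorophenyl on a carbonyl carbon. Going by the values given here, no measured step touches this place. Among the compounds with values here, the one step available, a 4.8-fold higher number from compound 1 to compound 2 (0.68 log units; beyond the scatter), concerns a different part of the molecule, the aromatic ring attached to the shared core, and so gives no direct guide here. With nothing that bears on it, the outcome is read as uncertain, with a small move in either direction or none beyond the scatter being plausible, and a wide range set around the starting point.

For compound 4 the expected value in this assay is estimated at 1500 nM, with a likely range from 450 nM to 5000 nM. Relative to compound 2 this estimate means a step of a 1.4-fold higher number from compound 2 to compound 4 (0.15 log units; within the scatter).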

Compound 4, half-maximal inhibitory concentration: 260 nM
Compound 4: the middle estimate sits 5.8-fold (0.76 log units) above what was measured, and the stated range ends above it.
By their numbers in this assay, from the lowest: compounds 1 and 4 (each within the scatter of the next); then compound 2.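

Swapping 4-chlorophenyl for pyridin-3-yl on the carbonyl carbon gives, in this assay, a 4.1-fold lower number from compound 2 to compound 4 (0.61 log units; beyond the scatter) and this is the first measured step at this place. It shows that this end of the molecule is not silent: with the trifluoromethyl group kept on the other aromatic ring, the change moves inhibition beyond the usual scatter, towards stronger inhibition. The swap removes the chlorine and also brings a nitrogen into the ring, and no measurement on hand explains the change or separates those two differences.

Still open, as far as these compounds go, is whether the same swap would give a similar step with methoxy in place of trifluoromethyl. Also open, from the compounds shown here alone, is how a plain phenyl, a pyridin-4-yl or a small amine such as morpholine would compare on that carbonyl carbon.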